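Swapping a para fluoro for nitro on the enone

The source may hold more compounds than are shown below. What is called first, only, known or untested is meant among the compounds shown, and "the series" means these compounds.

Compound 3 `CC(=O)OC/C(=C\c1ccc(F)cc1)C(=O)c1ccccc1` gives 17000 nM in a functional assay on HBL-100 cells (Homo sapiens) for inhibition, read by sulforhodamine B assay, with a stated time of 48 h (a lower number here means a stronger inhibitor of growth, a higher number a weaker inhibitor of growth), level with compound 1 `CC(=O)OC/C(=C\c1ccccc1)C(=O)c1ccccc1` at 17000 nM, together the highest numbers of the three; compound 2 `CC(=O)OC/C(=C\c1ccc(Cl)cc1)C(=O)c1ccccc1` gives 2300 nM. The change to compound 4 `CC(=O)OC/C(=C\c1ccc([N+](=O)[O-])cc1)C(=O)c1ccccc1` is nitro in place of fluoro on an aromatic carbon. Among the measured compounds shown here, no measured step involves nitro, so only the halogen steps bear on it: no change at the digits printed from compound 1 to compound 3 (within the scatter) and a 7.4-fold higher number from compound 2 to compound 3 (0.87 log units; beyond the scatter), showing that a group beyond fluoro at this position can lower the number, while fluoro alone did nothing. The step from compound 3 to compound 4 is therefore expected at about a 2.8-fold lower number from compound 3 to compound 4 (0.45 log units; beyond the scatter), a modest drop, but the direction is uncertain. For compound 4 the estimated value is 6000 nM, in a range from 1500 nM to 25000 nM.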

Compound 4, concentration for 50% growth inhibition: 10000 nM
The estimate for compound 4 lay 1.7-fold (0.22 log units) below the measured number; the range from low to high includes it.
By their numbers in this assay, from the lowest: compound 2; then compounds 4, 1 and 3 (each within the scatter of the next).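

In this assay, nitro on this aromatic carbon gives no clear gain over fluoro (a 1.7-fold lower number from compound 3 to compound 4 (0.23 log units; within the scatter)) or over hydrogen (a 1.7-fold lower number from compound 1 to compound 4 (0.23 log units; within the scatter)). Chloro stays apart from nitro (a 4.3-fold higher number from compound 2 to compound 4 (0.64 log units; beyond the scatter)), so among these four compounds, only chloro separates from hydrogen beyond the scatter. Nothing available explains why chloro and nitro differ here. From the compounds shown here alone, it remains open whether bromo, methyl or an amine at this position would follow chloro or stay with the other three, and whether moving chloro elsewhere on the ring would keep its step.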